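The source may report more compounds than this note shows. Statements on the series, on what has been measured and on what is new or still open speak of the compounds shown alone.

Compound 1 `CC(C)(O)COc1ccc2c(Oc3ccc(Nc4nccc5[nH]cc(-c6ccccc6)c(=O)c45)cc3F)ccnc2c1`: 4200 nM
Compound 2 `COCCOc1cc2nccc(Oc3ccc(Nc4nccc5[nH]cc(-c6ccc(F)cc6)c(=O)c45)cc3F)c2cc1OC`: 4600 nM
Compound 3 `O=c1c(-c2ccc(F)cc2)c[nH]c2ccnc(Nc3ccc(Oc4ccnc5cc(OCCO)ccc45)c(F)c3)c12`: 5500 nM

Of the compounds shown here, three built on a shared core have been tested in a functional assay on HT-29 cells (Homo sapiens) for antiproliferative activity, read by MTT assay, with a stated time of 72 h; on this read-out higher numbers stand for weaker inhibition and lower numbers for stronger inhibition. In this assay compound 3 gives 5500 nM, the highest of the three numbers. The nearest neighbour is compound 2 with 4600 nM, and the furthest is compound 1 with 4200 nM; both gaps lie within the usual scatter of repeated measurements, so the three compounds cannot be told apart on these numbers alone.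

Compound 4 `O=c1c(-c2ccc(F)cc2)c[nH]c2ccnc(Nc3ccc(Oc4ccnc5cc(O)ccc45)c(F)c3)c12` has not yet been measured in this assay. It differs from compound 3 in a single place:

hydrogen in place of 2-hydroxyethyl on an oxygen on an aromatic ring

Going by the values given here, no pair of measured compounds differs in only one place, so there is no step from which to read how a change of this kind has played out here. What is known is that the rest of the structure stays untouched and that a short tail of three heavy atoms is removed. On that basis a small step is expected, in either direction, and most likely none beyond the scatter. The step from compound 3 to compound 4 is therefore expected to be a 1.1-fold lower number from compound 3 to compound 4 (0.04 log units; within the scatter). Compound 4 is estimated at 5000 nM in this assay, with a range from 2000 nM to 14000 nM.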

Compound 4, half-maximal inhibitory concentration: 5900 nM
The estimate for compound 4 lay 1.2-fold (0.07 log units) below the measured number; the measured number falls inside the stated range.
By their numbers in this assay, from the lowest: compounds 1, 2, 3 and 4 (each within the scatter of the next).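

This is the first step among these compounds that changes only one place, and so it gives a direct reading of this oxygen on an aromatic ring. In this assay the change from 2-hydroxyethoxy to hydroxy gives a 1.1-fold higher number from compound 3 to compound 4 (0.03 log units; within the scatter) and stays within the scatter, so for this pair, removing the whole 2-hydroxyethyl group makes no difference that this read-out can detect. No supporting data bear on this result.

On these data alone, whether any group on this oxygen can shift the number remains open, and an amine-bearing chain, a carboxylic acid or a longer chain would show whether the flat result holds beyond hydrogen and 2-hydroxyethyl. A single pair also cannot say whether the same change would read the same way with the rest of the structure altered, as in compound 1, which carries a different tail and lacks the fluorine on its outer phenyl ring.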